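The source may report more compounds than this note shows. Statements on the series, on what has been measured and on what is new or still open speak of the compounds shown alone.

Measured in an ADME assay for permeability, using PAMPA, with a stated time of 4 h, at pH 7.4, tested at 100 uM; on this read-out lower numbers stand for lower permeability and higher numbers for higher permeability:
compound 1 `Cc1ccc(-c2cc3nc(C)c(C(OC(C)(C)C)C(=O)O)c(-c4cc(F)c5c(c4C)CCCO5)n3n2)cc1` gives 492 nm/s
compound 2 `Cc1ccccc1-c1cccc(-c2cc3nc(C)c([C@H](OC(C)(C)C)C(=O)O)c(-c4cc(F)c5c(c4C)CCCO5)n3n2)c1` gives 471 nm/s

Compound 2 stands beside compound 1, the two values lying within the scatter of each other, so on these numbers the pair cannot be told apart in this assay. Compound 3 `Cc1nc2cc(-c3cccc(-c4ccncc4)c3)nn2c(-c2cc(F)c3c(c2C)CCCO3)c1[C@H](OC(C)(C)C)C(=O)O` differs from compound 2 in one place: pyridin-4-yl in place of 2-methylphenyl on an aromatic carbon. Among the compounds with values here, no measured pair shows this change, so its size is open. In this assay the expected step is a 1.8-fold lower number from compound 2 to compound 3 (0.26 log units; within the scatter), a modest fall, though a result within the scatter would not be surprising. Compound 3 is estimated at 260 nm/s, ranging from 130 nm/s to 470 nm/s.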

Compound 3, apparent permeability: 488 nm/s
Estimate against measurement, compound 3: 1.9-fold (0.27 log units) below; the measured number lies above the stated range.
By their numbers in this assay, from the lowest: compounds 2, 3 and 1 (each within the scatter of the next).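

Within the data shown here, at this aromatic carbon, meta to a large group, pyridin-4-yl in place of 2-methylphenyl gives a 1.0-fold higher number from compound 2 to compound 3 (0.02 log units; within the scatter) in this assay as the first single-place step at this position. The change removes a carbon-only ring and brings in a ring with a hydrogen-bond acceptor, yet the two compounds cannot be told apart on this read-out. Nothing at hand explains this result.

As far as these compounds go, whether pyridin-3-yl would behave like pyridin-4-yl here remains open. So does whether an amine or a carboxylic acid on this ring would also stay within the scatter.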